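From ethyl to furan-2-yl: an expected cytotoxicity step

The source may hold more compounds than are shown below. What is called first, only, known or untested is meant among the compounds shown, and "the series" means these compounds.

compound 1 `CCC[S+]([O-])CCCCN=C=S` gives 5960 nM
compound 2 `[O-][S+](CCCCN=C=S)C1CCCC1` gives 4450 nM
compound 3 `COc1ccc(C[S+]([O-])CCCCN=C=S)cc1` gives 8890 nM

All three numbers come from a functional assay on MCF7 cells (Homo sapiens) for cytotoxicity, read by MTT assay, with a stated time of 72 h (on this read-out lower numbers stand for stronger inhibition and higher numbers for weaker inhibition), and share the same kind of read-out. In this set, compound 1 (5960 nM) stands within the usual scatter of both compound 2 and compound 3, so its number gives no sign of separating from either of them. Within the data shown here, no measured pair differs in one place only, and none of the three shows the coming change directly.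

The next compound to be tested is compound 4 `[O-][S+](CCCCN=C=S)Cc1ccco1`, which has furan-2-yl in place of ethyl on a saturated chain carbon bound to a sulfur. In this assay no step beyond the scatter is expected from this change, in either direction. That expectation rests on compound 2 (4450 nM) and compound 3 (8890 nM), which carry different groups and still stand within the scatter of compound 1 (5960 nM). The expected size of the change is small (a 1.0-fold higher number from compound 1 to compound 4 (0.00 log units; within the scatter)). The estimated value for compound 4 is 6000 nM (expected range 3000 nM to 11500 nM).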

Compound 4, half-maximal inhibitory concentration: 5680 nM
Beside the measured number, compound 4's estimate is 1.1-fold (0.02 log units) above it; the range from low to high includes it.
By their numbers in this assay, from the lowest: compounds 2, 4, 1 and 3 (each within the scatter of the next).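

Among these compounds, this is the first pair in the set that differs in one place only, so the change can be read on its own rather than inferred from compounds that differ in several ways. In this assay, furan-2-yl in place of ethyl on a saturated chain carbon bound to a sulfur gives a 1.0-fold lower number from compound 1 to compound 4 (0.02 log units; within the scatter), showing that this place accepts an aromatic five-membered ring carrying a hydrogen-bond acceptor without a step beyond the scatter. No available evidence bears on why the number stays level with the change of group.

As far as these compounds go, whether an amine or a carboxylic acid at this place, or a longer chain in place of ethyl, would produce a step beyond the scatter remains open. From the compounds shown here alone, this single pair speaks only for furan-2-yl against ethyl on the core of compound 1 in this one cell assay, so it is also open whether the same exchange would behave alike on other cell lines.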